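A few compounds are considered here, and "the series" means these few. Any claim that something is new, unique, unknown or untested is made for them only; others in the source may bear on it.

In a functional assay on HEK293 cells for agonist activity at probable G-protein coupled receptor 27 (Homo sapiens), read by a luciferase reporter and beta-arrestin recruitment, with a stated time of 10 min (on this read-out higher numbers stand for an effect only at larger amounts of compound and lower numbers for an effect already at smaller amounts), compound 2 `Cc1cc(Br)ccc1C(=O)Nc1ccc(S(=O)(=O)Nc2ccccc2)cc1` gives 851 nM, the higher of the two numbers measured there. Compound 3 `O=C(Nc1ccc(S(=O)(=O)Nc2ccccc2)cc1)c1ccc(C(F)(F)F)cc1F` gives 363 nM, a lower value, and this gap lies beyond the usual scatter of repeated measurements. Compound 1 `O=C(Nc1cccc(S(=O)(=O)Nc2ccccc2)c1)c1ccc(Cl)cc1Cl` reaches only a limit of that assay, > 100000 nM, which is not a number (the limit of > 100000 nM in this assay, at which 1 of the 3 values shown sits). Compound 4 `O=C(Nc1ccc(S(=O)(=O)Nc2ccccc2)cc1)c1ccc(Cl)cc1Cl` has not yet been measured in this assay. It differs from compound 2 by 2,4-dichlorophenyl in place of 4-bromo-2-methylphenyl on a carbonyl carbon. Among the compounds with values here, no measured pair shows this change, so only a step within the scatter, in either direction, is expected. Compound 4 is therefore estimated at 700 nM, with a likely range from 180 nM to 3000 nM. This estimate corresponds to an expected step of a 1.2-fold lower number from compound 2 to compound 4 (0.08 log units; within the scatter).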

Compound 4, half-maximal effective concentration: 457 nM
For compound 4 the middle estimate is 1.5-fold (0.19 log units) above the measured one; measured number inside the range.
By their numbers in this assay, from the lowest: compounds 3, 4 and 2 (each within the scatter of the next, the first and the last beyond it). At a limit, above all of these: compound 1.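

In this assay the exchange of 4-bromo-2-methylphenyl for 2,4-dichlorophenyl on a carbonyl carbon gives a 1.9-fold lower number from compound 2 to compound 4 (0.27 log units; within the scatter), so the two groups are not told apart at this place. The 2,4-dichlorophenyl group thus goes with a real number in compound 4, while compound 1, which also carries it, stays at a limit, > 100000 nM. Nothing shown here bears on why the two groups read alike.

All the groups shown on this carbonyl carbon are halogen-bearing phenyl rings. The compounds leave open how a piperidine ring or a plain butyl chain would read there.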